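Replacing the chloroalkyl amide by a propylurea

The source may hold more compounds than are shown below. What is called first, only, known or untested is meant among the compounds shown, and "the series" means these compounds.

Compound 1 `CC(=O)Nc1ccc(S(=O)(=O)Oc2ccccc2C(C)C)cc1`: 12000 nM
Compound 2 `CC(C)c1ccccc1OS(=O)(=O)c1ccc(NC(=O)CCl)cc1`: 1000 nM
Compound 3 `CC(C)c1ccccc1OS(=O)(=O)c1ccc(NC(=O)CCCl)cc1`: 6500 nM

All three compounds share one core and differ only in the group attached to the amide carbonyl. In a functional assay on HT-1080 cells (Homo sapiens) for antiproliferative activity, read by sulforhodamine B assay, with a stated time of 48 h (a higher number here means a weaker inhibitor, a lower number a stronger inhibitor), compound 3 gives 6500 nM, the second highest of the three numbers: the nearest is compound 1, with a 1.8-fold lower number from compound 1 to compound 3 (0.27 log units; within the scatter), and the furthest is compound 2, with a 6.5-fold higher number from compound 2 to compound 3 (0.81 log units; beyond the scatter).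

Compound 4 `CCCNC(=O)Nc1ccc(S(=O)(=O)Oc2ccccc2C(C)C)cc1` is not yet measured. It differs from compound 3 by propylamino in place of 2-chloroethyl on a carbonyl carbon, so the chlorine leaves and a urea-type nitrogen enters on the carbonyl carbon.

Going by the values given here, two measured steps bear on this. Putting chlorine directly on the carbon bound to the carbonyl gave a 12-fold lower number from compound 1 to compound 2 (1.08 log units; beyond the scatter), a large gain; moving it one carbon further out gave only a 1.8-fold lower number from compound 1 to compound 3 (0.27 log units; within the scatter), within the scatter. Compound 4 has no chlorine at all, so the feature that gave the large gain is absent, and the number is expected to be at the weaker end of the series, near compound 1 and compound 3. Compound 4 is therefore estimated at 10000 nM in this assay, with a range from 3000 nM to 30000 nM, meaning an expected step of a 1.5-fold higher number from compound 3 to compound 4 (0.19 log units; within the scatter).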

Compound 4, half-maximal inhibitory concentration: 680 nM
Estimate against measurement, compound 4: 15-fold (1.17 log units) above; measured number below the stated range.
By their numbers in this assay, from the lowest: compounds 4 and 2 (each within the scatter of the next); then compounds 3 and 1 (each within the scatter of the next).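

In this assay, putting propylamino in place of 2-chloroethyl on the carbonyl carbon gives a 9.6-fold lower number from compound 3 to compound 4 (0.98 log units; beyond the scatter), so a urea-type nitrogen is tolerated at this position and a chain without chlorine can still give a low number. Compared with chloromethyl, propylamino gives a 1.5-fold lower number from compound 2 to compound 4 (0.17 log units; within the scatter), so these two groups cannot be told apart in this assay, even though only one of them carries chlorine. Compared with methyl, propylamino gives an 18-fold lower number from compound 1 to compound 4 (1.25 log units; beyond the scatter), which shows that among these compounds a large step at this position can be reached with or without chlorine.

The compounds shown do not separate the contribution of the urea-type nitrogen from that of the propyl chain, and a butyl chain on the carbonyl carbon, or an ethylamino or butylamino group in the same place, would be needed to tell the two apart. Nothing given here shows why propylamino and chloromethyl end up with numbers so close together, or why propylamino differs so much from 2-chloroethyl.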